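The source may report more compounds than this note shows. Statements on the series, on what has been measured and on what is new or still open speak of the compounds shown alone.

Measured so far:
compound 1 `COc1cc2c(Oc3ccc(NC(=O)c4nn(-c5ccccc5)c(=O)c5ccccc45)cc3F)ccnc2cc1OCCCN1CCCC1`, 480 nM in a functional assay on NCI-H460 cells (Homo sapiens) for cytotoxicity, read by MTT assay, with a stated time of 72 h; a higher number here means a weaker inhibitor, a lower number a stronger inhibitor
compound 2 `COc1cc2c(Oc3ccc(NC(=O)c4nn(-c5ccccc5F)c(=O)c5ccccc45)cc3F)ccnc2cc1OCCCN1CCCC1`, 230 nM in this assay

Compound 2 has the lower of the two numbers; its nearest neighbour is compound 1, and the step of a 2.1-fold lower number from compound 1 to compound 2 (0.32 log units; beyond the scatter) lies beyond the scatter. Compound 3 `COc1cc2c(Oc3ccc(NC(=O)c4nn(-c5ccccc5F)c(=O)c5ccccc45)cc3F)ccnc2cc1OCCCN1CCC(C)CC1` has not been measured. It differs from compound 2 only in the basic amine at the end of the side chain: 4-methylpiperidin-1-yl in place of pyrrolidin-1-yl on a saturated chain carbon, three bonds along the chain from an oxygen on an aromatic ring. Within the data shown here, neither measured step touches this part of the molecule; the single step from compound 1 to compound 2 concerns a fluorine on an aromatic carbon of a distant ring, so it says nothing about the amine. With no guidance on this change, compound 3 is expected to show no step beyond the scatter, that is a 1.0-fold higher number from compound 2 to compound 3 (0.02 log units; within the scatter). In this assay compound 3 is therefore estimated at 240 nM, within a range from 100 nM to 600 nM.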

Compound 3, half-maximal inhibitory concentration: 200 nM
Beside the measured number, compound 3's estimate is 1.2-fold (0.08 log units) above it; measured number inside the range.
By their numbers in this assay, from the lowest: compounds 3 and 2 (each within the scatter of the next); then compound 1.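

In this assay, placing 4-methylpiperidin-1-yl instead of pyrrolidin-1-yl on the saturated chain carbon, three bonds along the chain from an oxygen on an aromatic ring, gives a 1.2-fold lower number from compound 2 to compound 3 (0.06 log units; within the scatter). Among these compounds, this is the first reading at the amine end of the side chain, and it shows that this position takes a six-membered ring carrying a methyl group in place of a five-membered ring with no change that this assay can resolve. Nothing available explains why the two amines read alike.

Still open, on these data alone, is how far this tolerance extends to other groups at the chain end, such as morpholin-4-yl or dimethylamino, or to a shorter or longer chain. Also open, as far as these compounds go, is how piperidin-1-yl without the methyl group would read, and whether the same amine exchange would read alike on compound 1.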